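This account rests on a few compounds, and the source may have more. Where it says the series, first, only, none or still open, it means among the compounds named here.

Within the data shown here, in an assay on NIH3T3 cells for binding affinity to melatonin receptor type 1B (Homo sapiens) (a higher number here means a weaker inhibitor, a lower number a stronger inhibitor), compound 3 `COc1cccc2[nH]c(CNC(C)=O)cc12` gives 813 nM, the second highest of the three numbers so far. Its nearest neighbour is compound 2 `CCC(=O)NCc1cc2c(OC)cccc2[nH]1`, which gives 288 nM in this assay, while compound 1 `COc1ccc2[nH]c(CCCNC(C)=O)cc2c1` gives 102000 nM. Among the measured compounds shown here, the only single-point step among the measured compounds runs a 2.8-fold higher number from compound 2 to compound 3 (0.45 log units; beyond the scatter). Compound 4 `COc1cccc2[nH]c(CNC(=O)C3CCC3)cc12` differs from compound 3 by cyclobutyl in place of methyl on a carbonyl carbon. This is the same amide end enlarged in the opposite sense to that step, so a lowering of the number is expected, of a size comparable to or somewhat beyond the step from compound 2 to compound 3. Compound 4 is therefore estimated at 110 nM in this assay, with a range from 30 nM to 400 nM, a step of a 7.4-fold lower number from compound 3 to compound 4 (0.87 log units; beyond the scatter).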

Compound 4, inhibition constant: 646 nM
Estimate against measurement, compound 4: 5.9-fold (0.77 log units) below; the measured number lies above the stated range.
By their numbers in this assay, from the lowest: compound 2; then compounds 4 and 3 (each within the scatter of the next); then compound 1.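

On the carbonyl carbon, cyclobutyl in place of methyl gives a 1.3-fold lower number from compound 3 to compound 4 (0.10 log units; within the scatter) in this assay, so this larger ring does not separate the two compounds. Cyclobutyl in place of ethyl gives a 2.2-fold higher number from compound 2 to compound 4 (0.35 log units; beyond the scatter), so at this place compound 2 stands apart from both compound 3 and compound 4, and the number does not follow the size of the group across these three compounds. Nothing shown here gives a reason for this.

Going by these compounds, whether cyclopropyl, a longer chain or an amine on the carbonyl carbon would give a number lower than that of compound 2 remains open.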